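Rearranging the Fused Ring in a Cytotoxic Amide Series

A few compounds are considered here, and "the series" means these few. Any claim that something is new, unique, unknown or untested is made for them only; others in the source may bear on it.

Three compounds have so far been measured in a functional assay on A549 cells (Homo sapiens) for cytotoxicity, read by MTT assay, with a stated time of 72 h; a higher number here means a weaker inhibitor, a lower number a stronger inhibitor:

compound 1 `Cc1cc(=O)n(-c2ccc(Br)cc2F)nc1C(=O)Nc1ccc(Oc2ncnc3ccsc23)c(F)c1` gives 2980 nM
compound 2 `Cc1cc(=O)n(-c2cccc(F)c2)nc1C(=O)Nc1ccc(Oc2ncnc3ccsc23)c(F)c1` gives 5220 nM
compound 3 `Cc1ccc(-n2nc(C(=O)Nc3ccc(Oc4ncnc5ccsc45)c(F)c3)c(C)cc2=O)cc1` gives 5890 nM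

Compound 1 has the lowest number of the three, but its steps to the others, a 1.8-fold higher number from compound 1 to compound 2 (0.24 log units; within the scatter) and a 2.0-fold higher number from compound 1 to compound 3 (0.30 log units; within the scatter), both stay within the scatter, as does a 1.1-fold higher number from compound 2 to compound 3 (0.05 log units; within the scatter), so no ranking among them can be claimed. All three measured steps change only the aryl group on the aromatic nitrogen of the shared core.

Compound 4 `Cc1cc(=O)n(-c2ccc(Br)cc2F)nc1C(=O)Nc1ccc(Oc2ncnc3sccc23)c(F)c1` differs from compound 1 elsewhere: a group of 9 heavy atoms (6 carbon, 2 nitrogen, 1 sulfur; one five-membered aromatic ring with 1 hetero atom, one six-membered aromatic ring with 2 hetero atoms) in place of a group of 9 heavy atoms (6 carbon, 2 nitrogen, 1 sulfur; one five-membered aromatic ring with 1 hetero atom, one six-membered aromatic ring with 2 hetero atoms), on an oxygen on an aromatic ring. The two have the same atoms, joined differently. Among the measured compounds shown here, no measured step touches this part of the molecule, so nothing measured bears directly on the change, and the only guide is the general observation that modest changes have all stayed within the scatter.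

For compound 4 the step of a 1.1-fold higher number from compound 1 to compound 4 (0.03 log units; within the scatter) is therefore expected to lie within the scatter. Compound 4 is estimated at 3200 nM, with a range from 1400 nM to 7500 nM.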

Compound 4, half-maximal inhibitory concentration: 11500 nM
For compound 4 the middle estimate is 3.6-fold (0.56 log units) below the measured one; the whole stated range lies below it.
By their numbers in this assay, from the lowest: compounds 1, 2, 3 and 4 (each within the scatter of the next, the first and the last beyond it).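

With the same atoms and the same counts of hydrogen-bond donors and acceptors in both groups, the way those atoms are joined in the group on the oxygen is enough to give a 3.9-fold higher number from compound 1 to compound 4 (0.59 log units; beyond the scatter) in this assay. This position therefore responds to rearrangement alone, whereas the aryl groups on the aromatic nitrogen of compounds 1, 2 and 3 all stayed within the scatter of one another. Nothing available here accounts for this difference.

Going by these compounds, it remains open whether the same rearrangement would give a similar step with 3-fluorophenyl or 4-methylphenyl on the aromatic nitrogen. Also open, on these data alone, is how the number would respond if a simple pyridine ring or a phenyl ring carrying an amine stood on the oxygen.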